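The source may hold more compounds than are shown below. What is called first, only, known or untested is meant among the compounds shown, and "the series" means these compounds.

Measured in a functional assay on A549 cells (Homo sapiens) for cytotoxicity, read by MTT assay; on this read-out lower numbers stand for stronger inhibition and higher numbers for weaker inhibition:

Compound 1 `CC(C)C[C@@H](NC(=S)Nc1ccccc1)c1nc2ccccc2[nH]1` — 18700 nM
Compound 2 `CC(C)C[C@H](NC(=S)Nc1ccccc1)c1nc2ccccc2[nH]1` — 28600 nM
Compound 3 `CC(C)[C@@H](NC(=S)Nc1cc(C(F)(F)F)cc(C(F)(F)F)c1)c1nc2ccccc2[nH]1` — 22400 nM

Compound 2 carries the highest of the three numbers, yet its gap to compound 3 and its gap to compound 1 both fall within the scatter, so the three compounds cannot be ranked against each other. Among the measured compounds shown here, the one single-point step measured here, a 1.5-fold higher number from compound 1 to compound 2 (0.18 log units; within the scatter), is itself within the scatter, and it rests on the fact that compounds 1 and 2 differ only in the configuration as drawn — a change of configuration alone, with the isobutyl chain kept in place.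

Compound 4 `C[C@H](NC(=S)Nc1ccccc1)c1nc2ccccc2[nH]1` is the next step from compound 2: hydrogen in place of isopropyl on a saturated chain carbon, two bonds along the chain from an amide-type nitrogen and an aromatic carbon. For the measured compounds named here, no measured step in this assay removes the isopropyl while holding everything else fixed. Compound 3 carries a shorter chain and a different aryl group at once, so its value stands only as a second point near the others, not as a guide to this change. With no step beyond the scatter anywhere in the data, compound 4 is expected to sit close to compound 2, with a step of a 1.0-fold higher number from compound 2 to compound 4 (0.02 log units; within the scatter). The estimate for compound 4 in this assay is 30000 nM, within 10000 nM to 90000 nM.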

Compound 4, half-maximal inhibitory concentration: 188000 nM
Estimate against measurement, compound 4: 6.3-fold (0.80 log units) below, and the stated range ends below it.
By their numbers in this assay, from the lowest: compounds 1, 3 and 2 (each within the scatter of the next); then compound 4.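

In this assay, among the compounds shown here, cutting the isobutyl back to methyl gives a 6.6-fold higher number from compound 2 to compound 4 (0.82 log units; beyond the scatter), the first step in this set that lies beyond the scatter. For the compounds shown here, until now, the only step read at this saturated chain carbon was a 1.5-fold higher number from compound 1 to compound 2 (0.18 log units; within the scatter), which lies within the scatter, so the new result shows that the group carried there matters to the read-out, at least for this pair. The contrast with a step beyond the scatter rests on a pair that isolates configuration: the fact that compounds 1 and 2 differ only in the configuration as drawn

The compounds shown leave open how the number runs between methyl and isobutyl, and what an ethyl group, a longer chain or a chain ending in an amine or a carboxylic acid would give on this carbon. They also leave open whether configuration at this carbon matters any more when the group there is methyl.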